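The source may hold more compounds than are shown below. What is called first, only, known or untested is meant among the compounds shown, and "the series" means these compounds.

Among the compounds with values here, compound 3 `OCCn1cc2c(Nc3ccc(OC(F)(F)F)cc3)ncnc2n1` is one of three compounds measured in an ADME assay on BaF3 cells (Mus musculus) for cytotoxicity; on this read-out higher numbers stand for an effect only at larger amounts of compound and lower numbers for an effect already at smaller amounts. In this assay compound 3 gives > 10000 nM, which is a limit of the assay and not a number. Compound 1 `CCCn1cc2c(Nc3ccc(OC(F)(F)F)cc3)ncnc2n1` in this assay gives > 10000 nM, again a limit. Compound 2 `FC(F)(F)Oc1ccc(Nc2ncnc3nn(C4CCCCC4)cc23)cc1` in this assay gives > 10000 nM, also a limit. Within the data shown here, all three values sit at the same place, (the limit of > 10000 nM in this assay, at which 3 of the 3 values shown sit), and with every value at that limit none of the measured steps can be read: the step that the two limits leave unreadable from compound 1 to compound 3, the step that the two limits leave unreadable from compound 2 to compound 3 and the step that the two limits leave unreadable from compound 1 to compound 2 each changed the group on the aromatic nitrogen without moving the read-out off its limit.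

Compound 4 `FC(F)(F)Oc1ccc(Nc2ncnc3nn(Cc4cccnc4)cc23)cc1` differs from compound 3 in one place: pyridin-3-yl in place of hydroxymethyl on a saturated chain carbon bound to an aromatic nitrogen. The groups on that nitrogen have so far ranged from a propyl through a cyclohexyl to a 2-hydroxyethyl, and every one of these left the read-out at the limit. Among the measured compounds shown here, the (pyridin-3-yl)methyl lies outside what has been tried, and no measured step tells its direction. Compound 4 is nonetheless expected to stay at the limit as well, with the step that the limit leaves unreadable from compound 3 to compound 4 expected to be none beyond the scatter. The estimate for compound 4 is 15000 nM, between 5000 nM and 50000 nM.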

Compound 4, half-maximal effective concentration: > 10000 nM
Compound 4 ended at the assay's limit; the forecaster's own chance of this, stated with the estimate: 85%; the middle value is on the limit's open side.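

No new step can be read: compound 4, like compound 1, compound 2 and compound 3, stands at a limit of this assay and not at a number, so the steps between them remain unreadable: the limit of > 10000 nM in this assay, at which 4 of the 4 values shown sit. The compounds shown leave open whether any group on the aromatic nitrogen would bring the read-out off this limit.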